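A few compounds are considered here, and "the series" means these few. Any claim that something is new, unique, unknown or untested is made for them only; others in the source may bear on it.

Measured compounds in a functional assay on HEp-2 cells (Homo sapiens) for cytotoxicity, read by MTT assay, with a stated time of 72 h; a lower number here means a stronger inhibitor, a higher number a weaker inhibitor:

- compound 1 `O=c1cc(CSc2nc3ccccc3s2)oc2ccccc12`: compound 1 gives > 25000 nM, a limit of the assay rather than a number.
- compound 2 `O=c1cc(CSc2nc3ccccc3s2)oc2ccc(Cl)cc12`: compound 2 gives > 25000 nM, again only a limit.
- compound 3 `Nc1nnc(SCc2cc(=O)c3ccccc3o2)s1`: compound 3 gives > 25000 nM, also a limit.

Compound 2 therefore stands at the limit of > 25000 nM in this assay, at which 3 of the 3 values shown sit, with no number of its own. The step that the two limits leave unreadable from compound 1 to compound 2 is the only measured one touching the same place, and it cannot be read. Compound 4 `Cc1ccc2oc(CSc3nc4ccccc4s3)cc(=O)c2c1` differs from compound 2 by methyl in place of chloro on an aromatic carbon. With no readable step to draw on, no change beyond the scatter is expected in this assay, and compound 4 is expected to remain at the limit. The estimate for compound 4 is 40000 nM, between 15000 nM and 150000 nM. The expected step is a step that the limit leaves unreadable from compound 2 to compound 4.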

Compound 4, half-maximal inhibitory concentration: > 25000 nM
Compound 4: no number, only a limit; the forecaster's own chance of this, stated with the estimate: 85%; the middle value is on the limit's open side.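

Compound 4 gives > 25000 nM, a limit of the assay and not a number, so its steps from compound 1 and compound 2 cannot be read. The compounds shown leave open whether chloro or methyl changes cytotoxicity at all.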